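The source may report more compounds than this note shows. Statements on the series, on what has been measured and on what is new or still open speak of the compounds shown alone.

Compound 1 `CNC(=O)C1CCCC1n1cnc2c(NC3CC3)ncnc21`: in an assay on cell membranes for displacement of a labelled ligand from adenosine receptor A1 (Rattus norvegicus), tested at 100 uM (a lower number here means less inhibition, a higher number more inhibition at the concentration tested (going by the name of the read-out)), compound 1 reaches only a limit of the assay, < 10%.
Compound 2 `CNC(=O)C1CCCC1n1cnc2c(NC3CCCC3)ncnc21`: in this assay compound 2 gives 31%.

Among the compounds with values here, compound 2 thus holds the only real number in this small set; the other value is a limit. Within the data shown here, the one measured step, a number at least 21 percentage points higher from compound 1 to compound 2 (beyond the scatter), came from cyclopentyl in place of cyclopropyl on a nitrogen on an aromatic ring. Compound 3 `CNC(=O)C1CCCC1n1cnc2c(NCc3ccccc3)ncnc21` alters that same nitrogen: benzyl in place of cyclopentyl on a nitrogen on an aromatic ring. Among the measured compounds shown here, no measured step exchanges cyclopentyl for benzyl, so the step from compound 1 to compound 2 is the only guide. It shows that enlarging the group on this nitrogen moved inhibition upward, and benzyl brings more heavy atoms still, so a modest further rise in this assay is expected, though the direction is uncertain with a single guide. Compound 3 is expected to give 40%, between 15% and 65%. That corresponds to an expected step of a number 9 percentage points higher from compound 2 to compound 3 (within the scatter).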

Compound 3, a percentage reported as inhibition, at one concentration (the size of the read-out at that concentration, not a potency): 26%
For compound 3 the middle estimate is 14 percentage points above the measured one; the measured number falls inside the stated range.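

In this assay, benzyl in place of cyclopentyl gives a number 5 percentage points lower from compound 2 to compound 3 (within the scatter), so these two groups cannot be told apart on this nitrogen, even though benzyl carries more heavy atoms. The rise seen on leaving cyclopropyl therefore does not simply continue as heavy atoms are added, although benzyl in place of cyclopropyl still gives a number at least 16 percentage points higher from compound 1 to compound 3 (beyond the scatter), which sets both cyclopentyl and benzyl apart from cyclopropyl. The true size of that step stays unknown because compound 1 sits at a limit of the assay: the limit of < 10% in this assay, at which 1 of the 3 values shown sits.

Open, going by these compounds, is whether a phenethyl group, with a longer chain to the aromatic ring, or a pyridylmethyl group, with a ring nitrogen, would behave like benzyl here. A single tested concentration also leaves the actual potencies of compound 2 and compound 3 unknown.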